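Sulfonate ureas: isopropyl to iodo on a second core

The compounds below may be only part of what the source reports. "The series", "measured", "known", "first", "only" and "open" are said of these compounds alone.

Measured compounds:
compound 1 `CCNC(=O)Nc1ccc(S(=O)(=O)Oc2ccccc2C(C)C)cc1` with 1100 nM
compound 2 `CCNC(=O)Nc1ccc(S(=O)(=O)Oc2ccccc2I)cc1` with 5300 nM
compound 3 `CC(C)c1ccccc1OS(=O)(=O)c1ccc(NC(=O)NCC2CCCC2)cc1` with 6800 nM

In a functional assay on HT-29 cells (Homo sapiens) for antiproliferative activity, read by sulforhodamine B assay, with a stated time of 48 h (a higher number here means a weaker inhibitor, a lower number a stronger inhibitor), compound 1 gives 1100 nM, the lowest number of the three. Compound 2 differs from compound 1 by one change, (iodo in place of isopropyl on an aromatic carbon), and the step is a 4.8-fold higher number from compound 1 to compound 2 (0.68 log units; beyond the scatter). Compound 3 differs from compound 1 in another place, (cyclopentyl in place of methyl on a saturated chain carbon bound to an amide-type nitrogen), and this step is a 6.2-fold higher number from compound 1 to compound 3 (0.79 log units; beyond the scatter). Compound 2 and compound 3 lie within the scatter of each other.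

Compound 4 `O=C(NCC1CCCC1)Nc1ccc(S(=O)(=O)Oc2ccccc2I)cc1` has not been measured in this assay. It is related to compound 3 as compound 2 is to compound 1: iodo in place of isopropyl on an aromatic carbon. The place lines of the two changes read the same word for word, so this is the same change made on the core of compound 3, whose difference from the core of compound 1 is given above. Resting on the measured step from compound 1 to compound 2, the step from compound 3 to compound 4 is expected to be similar, a 4.1-fold higher number from compound 3 to compound 4 (0.61 log units; beyond the scatter). Compound 4 is accordingly expected to give about 28000 nM, with a range from 9000 nM to 80000 nM.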

Compound 4, half-maximal inhibitory concentration: 7600 nM
The estimate for compound 4 lay 3.7-fold (0.57 log units) above the measured number; the whole stated range lies above it.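

On the core of compound 3, iodo in place of isopropyl gives a 1.1-fold higher number from compound 3 to compound 4 (0.05 log units; within the scatter) in this assay, so the change does not carry over at the size it had on the core of compound 1: the same change on two cores in this assay, a 4.8-fold higher number (0.68 log units; beyond the scatter) from compound 1 to compound 2 and a 1.1-fold higher number (0.05 log units; within the scatter) from compound 3 to compound 4, 4.3-fold (0.63 log units) apart, beyond the scatter of two such steps

Read from the other place, cyclopentyl in place of methyl gives a 1.4-fold higher number from compound 2 to compound 4 (0.16 log units; within the scatter), and this too stands apart from its earlier counterpart: the same change on two cores in this assay, a 6.2-fold higher number (0.79 log units; beyond the scatter) from compound 1 to compound 3 and a 1.4-fold higher number (0.16 log units; within the scatter) from compound 2 to compound 4, 4.3-fold (0.63 log units) apart, beyond the scatter of two such steps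

The effect of each change thus depends on what stands at the other place, but both comparisons rest on the same four compounds and so count as one observation, which shows neither why the steps differ nor how the change would behave on any further core.

The compounds shown leave open whether the step from isopropyl to iodo would stay large or vanish with another group on the urea nitrogen, such as a propyl chain or a cyclohexylmethyl group. They also leave open how a bromo or a tert-butyl group at the same place would behave on either core.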